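A Pyridinyl Triazole Analogue Set Against Three Inactive Precursors

The source may report more compounds than this note shows. Statements on the series, on what has been measured and on what is new or still open speak of the compounds shown alone.

Compound 1 `C=C1C[C@]23C[C@@]1(O)CC[C@H]2c1ccc(OS(=O)(=O)c2ccc(C)cc2)c(C)c1[C@@H]3Cn1cc(-c2ccc(Br)cc2)nn1` gives > 20000 nM in a functional assay on HL-60 cells (Homo sapiens) for cytotoxicity, read by MTT assay, with a stated time of 4 days; on this read-out lower numbers stand for stronger inhibition and higher numbers for weaker inhibition.
Compound 2 `C=C1C[C@]23C[C@@]1(O)CC[C@H]2c1ccc(O)c(C)c1[C@@H]3Cn1cc(-c2ccc(Br)cc2)nn1` gives > 20000 nM in this assay.
Compound 3 `Cc1ccc(S(=O)(=O)Oc2ccc3c(c2C)[C@H](Cn2cc(-c4ccc(F)cc4)nn2)[C@@]24CC(=O)[C@@](C)(CC[C@@H]32)C4)cc1` gives > 20000 nM in this assay.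

Compound 1 stands at a limit of the assay rather than at a number: the limit of > 20000 nM in this assay, at which 3 of the 3 values shown sit. Among the compounds with values here, the single step between measured compounds that differ in one place, a step that the two limits leave unreadable from compound 1 to compound 2, cannot be read because both ends are limits. Compound 3 likewise sits at the limit. Compound 4 `C=C1C[C@]23C[C@@]1(O)CC[C@H]2c1ccc(OS(=O)(=O)c2ccc(C)cc2)c(C)c1[C@@H]3Cn1cc(-c2ccccn2)nn1` differs from compound 1 by pyridin-2-yl in place of 4-bromophenyl on an aromatic carbon. Within the data shown here, no measured step touches this part of the structure; the one measured step concerns the oxygen on the aromatic ring, and it is unreadable. There is therefore no basis for expecting a step beyond the scatter in this assay in either direction, and the three limits together make a further limit the most likely outcome. Compound 4 is expected to give about 20000 nM, with a range from 8000 nM to 100000 nM. The expected step is a number no higher from compound 1 to compound 4 (the limit leaves the size open), that is, nothing beyond the scatter.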

Compound 4, half-maximal inhibitory concentration: > 20000 nM
Compound 4 ended at the assay's limit (the forecaster's own chance of this, stated with the estimate: 80%); the middle value sits exactly at the limit.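

Compound 1 and compound 4 both stand at a limit of the assay rather than at a number, so no size can be read for pyridin-2-yl in place of 4-bromophenyl: the limit of > 20000 nM in this assay, at which 4 of the 4 values shown sit.
The compounds shown leave open whether any change to this shared core gives a measurable number in this assay at all.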